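Sulfamoyl for methoxy on the shared core of compound 1

The source may report more compounds than this note shows. Statements on the series, on what has been measured and on what is new or still open speak of the compounds shown alone.

Compound 1 `COc1ccc(Nc2nc3cc(C(=O)Nc4ccccc4OC)ccc3n2Cc2ccccc2C(F)(F)F)cc1` stands only as a limit in an assay on isolated protein for inhibition of kinesin heavy chain isoform 5A (Homo sapiens); on this read-out higher numbers stand for weaker inhibition and lower numbers for stronger inhibition: compound 1 gives > 50000 nM, a limit of the assay and not a number. Two relatives share the sulfamoylphenyl amine but carry different groups on the ring nitrogen of the core. Compound 2 `NC(=O)c1ccc2c(c1)nc(Nc1ccc(S(N)(=O)=O)cc1)n2C1(c2ccccc2)CC1` gives > 50000 nM in this assay, again a limit. Compound 3 `NC(=O)c1ccc2c(c1)nc(Nc1ccc(S(N)(=O)=O)cc1)n2Cc1csc2ccc(Cl)cc12` gives > 50000 nM in this assay, also a limit. The step that the two limits leave unreadable from compound 2 to compound 3 therefore cannot be read. Going by the values given here, the common ground of the series so far is the limit of > 50000 nM in this assay, at which 3 of the 3 values shown sit.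

Compound 4 `COc1ccccc1NC(=O)c1ccc2c(c1)nc(Nc1ccc(S(N)(=O)=O)cc1)n2Cc1ccccc1C(F)(F)F` is not yet measured. From compound 1 it differs by sulfamoyl in place of methoxy on an aromatic carbon; this brings in the sulfamoylphenyl amine already present in compound 2 and compound 3. Among the compounds with values here, no measured step bears on this change with a readable size: the one step known, between compound 2 and compound 3, is hidden by two limits. Within the data shown here, with every value so far sitting at the limit, compound 4 is expected to remain at or near that limit in this assay, the expected step being a step that the limit leaves unreadable from compound 1 to compound 4, not beyond the scatter. The estimate for compound 4 is 60000 nM, with a range from 20000 nM to 300000 nM.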

Compound 4, half-maximal inhibitory concentration: > 50000 nM
Compound 4 gave a limit, no number (the forecaster's own chance of this, stated with the estimate: 85%); the middle value does not contradict the limit.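

Compound 1 and compound 4 both stand only as limits in this assay, so no size can be read for sulfamoyl in place of methoxy, and the series stays at one common limit: the limit of > 50000 nM in this assay, at which 4 of the 4 values shown sit. Still open, on these data alone, is which change on the shared core, if any, gives a number rather than a limit in this assay.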